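A Smaller Ring on the Sulfur of Compound 1

A few compounds are considered here, and "the series" means these few. Any claim that something is new, unique, unknown or untested is made for them only; others in the source may bear on it.

Compound 1 `O=C(Nc1cc(Sc2ncnc3nc[nH]c23)c(O)c2ccccc12)c1ccc(Cl)cc1`: 23000 nM
Compound 2 `O=C(Nc1cc(Sc2ncnc3nc[nH]c23)c(O)c2ccccc12)c1ccc([N+](=O)[O-])cc1`: > 100000 nM
Compound 3 `COc1cccc(C(=O)Nc2cc(Sc3ncn[nH]3)c(O)c3ccccc23)c1`: > 100000 nM

Among the measured compounds shown here, in a functional assay on MDA-MB-231 cells (Homo sapiens) for antiproliferative activity, read by MTT assay, with a stated time of 48 h (a lower number here means a stronger inhibitor, a higher number a weaker inhibitor), compound 1 gives 23000 nM, the only plain number among the three measured compounds. Compound 2 reaches only a limit of the assay, > 100000 nM. Compound 3 likewise stops at a limit, > 100000 nM. For the measured compounds named here, the one step between compounds that differ in a single place, an at least 4.3-fold higher number from compound 1 to compound 2 (0.63 log units; beyond the scatter), runs from a number to a limit, so its true size is only a lower bound; this rests on (the limit of > 100000 nM in this assay, at which 2 of the 3 values shown sit).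

Compound 4 `Cn1nnnc1Sc1cc(NC(=O)c2ccc(Cl)cc2)c2ccccc2c1O` differs from compound 1 on the sulfur: a group of 6 heavy atoms (2 carbon, 4 nitrogen; one five-membered aromatic ring with 4 hetero atoms) in place of a group of 9 heavy atoms (5 carbon, 4 nitrogen; one five-membered aromatic ring with 2 hetero atoms, one six-membered aromatic ring with 2 hetero atoms), on a sulfur. Going by the values given here, no measured pair changes the group on the sulfur alone, so no step here bears directly on this change. Compound 3 carries a different small ring on the sulfur together with a changed amide and sits at a limit, but it shares no single-place comparison with compound 1. With compound 1 already weak and the ring being exchanged for a smaller one, compound 4 is expected to move a 2.0-fold higher number from compound 1 to compound 4 (0.29 log units; within the scatter), toward weaker inhibition in this assay. The estimate for compound 4 is 45000 nM, with a range from 12000 nM to 150000 nM.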

Compound 4, half-maximal inhibitory concentration: > 100000 nM
Compound 4: only a limit was reported; the forecaster's own chance of this, stated with the estimate: 40%; middle value at least 2.2-fold (0.34 log units) away from the limit.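

Among the compounds shown here, compound 4 gives the first single-place reading of the group on the sulfur: with the rest of compound 1 kept and 1-methyl-1H-tetrazol-5-yl in the place of the two-ring group, this assay shows an at least 4.3-fold higher number from compound 1 to compound 4 (0.63 log units; beyond the scatter). The group on the sulfur is therefore not a free position for this exchange, and compound 1 remains the only compound shown that gives a plain number, as the change on the sulfur and the nitro in place of chloro both end at a limit. For compound 4 the value of > 100000 nM is a limit and not a number, so the step gives only a lower bound on the real change: the limit of > 100000 nM in this assay, at which 3 of the 4 values shown sit.

The compounds shown do not separate the smaller ring from the other differences in this exchange, such as the hydrogen-bond donor that the leaving group has and 1-methyl-1H-tetrazol-5-yl lacks. They also leave open how a benzyl group, or a longer chain ending in a carboxylic acid, would behave on the same sulfur.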